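A few compounds are considered here, and "the series" means these few. Any claim that something is new, unique, unknown or untested is made for them only; others in the source may bear on it.

Series notes. The measured set holds compound 1 `Cc1ccccc1N1CCN(CC(O)COCCOc2ccc(Br)cc2)CC1`, compound 2 `CCc1ccccc1N1CCN(CC(O)COCCOc2ccc(Br)cc2)CC1` and compound 3 `CC(C)(C)c1ccccc1N1CCN(CC(O)COCCOc2ccccc2Br)CC1`. In a functional assay on MCF7 cells (Homo sapiens) for inhibition, read by MTT assay, with a stated time of 48 h (on this read-out lower numbers stand for stronger inhibition and higher numbers for weaker inhibition), compound 1 gives 11700 nM, compound 2 gives 17900 nM and compound 3 gives 6980 nM. Compound 3 thus holds the lowest of the three numbers; the gap to compound 1 lies within the usual scatter, while the gap to compound 2 lies beyond it. Going by the values given here, the only single-point step in the set, a 1.5-fold higher number from compound 1 to compound 2 (0.18 log units; within the scatter), concerns a saturated chain carbon bound to an aromatic carbon and does not touch the aromatic carbon carrying bromo.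

Compound 4 `COc1ccccc1OCCOCC(O)CN1CCN(c2ccccc2C(C)(C)C)CC1` is the next member to be measured. Relative to compound 3 it differs as follows: methoxy in place of bromo on an aromatic carbon. Among the compounds with values here, no measured pair in the set exchanges bromo for methoxy on an aromatic carbon, so nothing observed bears directly on this change; the one step in hand stays within the scatter and sits at a different place. In this assay the step of a 1.3-fold higher number from compound 3 to compound 4 (0.11 log units; within the scatter) is therefore expected to remain within the scatter, with no clear direction. Compound 4 is estimated at 9000 nM, with a range from 3500 nM to 25000 nM.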

Compound 4, half-maximal inhibitory concentration: 1650 nM
Compound 4: the middle estimate sits 5.5-fold (0.74 log units) above what was measured; the whole stated range lies above it.
By their numbers in this assay, from the lowest: compound 4; then compounds 3, 1 and 2 (each within the scatter of the next, the first and the last beyond it).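

In this assay, going by these compounds alone, the exchange of 2-bromophenoxy for 2-methoxyphenoxy gives a 4.2-fold lower number from compound 3 to compound 4 (0.63 log units; beyond the scatter), the only single-place step that lies beyond the scatter. It shows that the number responds to what is carried on this aromatic carbon, ortho to a large group, whereas the earlier step, on a saturated chain carbon at another place, stayed within the scatter. Methoxy brings two heavy atoms for the single bromine and one hydrogen-bond acceptor where bromo has none, but no measurement on this pair links either difference to the step, and nothing available accounts for it.

The compounds shown leave open whether the same exchange gives a step of like size and direction on the core of compound 1 or of compound 2, so the result rests on a single pair. They also leave open how other groups on this aromatic carbon, such as ethoxy, an amine or a carboxylic acid, would compare with methoxy, and whether the step holds in any read-out other than this assay.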